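From methoxymethyl to dimethylamino on a carbonyl carbon

A few compounds are considered here, and "the series" means these few. Any claim that something is new, unique, unknown or untested is made for them only; others in the source may bear on it.

In an ADME assay on HEK293 cells (Homo sapiens) for cytotoxicity (a lower number here means a stronger inhibitor, a higher number a weaker inhibitor), compound 1 `O=C(N[C@H]1CN(C(=O)c2ccccc2)C[C@H]1NC(=O)c1ccc(Cl)s1)c1ccc(-n2ccccc2=O)cc1` gives > 100000 nM as a limit of the assay and not a number. Compound 2 `COCC(=O)N1C[C@H](NC(=O)c2ccc(-n3ccccc3=O)cc2)[C@H](NC(=O)c2ccc(Cl)s2)C1` gives > 100000 nM as a limit too. Compound 3 `COC(=O)N1C[C@H](NC(=O)c2ccc(-n3ccccc3=O)cc2)[C@H](NC(=O)c2ccc(Cl)s2)C1` gives > 100000 nM as a limit as well. All that has been measured so far therefore comes down to the limit of > 100000 nM in this assay, at which 3 of the 3 values shown sit, and no exact reading, so compound 2 stands with the other two.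

Compound 4 `CN(C)C(=O)N1C[C@H](NC(=O)c2ccc(-n3ccccc3=O)cc2)[C@H](NC(=O)c2ccc(Cl)s2)C1` has not been measured yet. It keeps the core of compound 2 and differs in one group, as dimethylamino in place of methoxymethyl on a carbonyl carbon shows, with dimethylamino in place of methoxymethyl on a carbonyl carbon.

Three measured changes on a carbonyl carbon bear on this one, namely a step that the two limits leave unreadable from compound 1 to compound 2 together with a step that the two limits leave unreadable from compound 1 to compound 3 and a step that the two limits leave unreadable from compound 2 to compound 3 and none of them gives a size. Phenyl, methoxymethyl and methoxy on that carbon all left the reading at the limit, so no step beyond the scatter is expected in this assay and no direction can be named. The expected step is a number no higher from compound 2 to compound 4 (the limit leaves the size open) as estimated from these limits. For compound 4 the estimated value is 100000 nM with an expected range from 50000 nM to 200000 nM and a further limit is the likeliest report.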

Compound 4, half-maximal inhibitory concentration: > 100000 nM
Compound 4: a limit, no number; the forecaster's own chance of this, stated with the estimate: 85%; the middle value lies on the limit itself.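

No size can be read for the steps linking compound 4 to compound 1, compound 2 and compound 3, because all four compounds give only a limit of the assay and not a number: the limit of > 100000 nM in this assay, at which 4 of the 4 values shown sit.

The compounds shown leave open whether phenyl, methoxymethyl, methoxy and dimethylamino on the carbonyl carbon differ at all in this assay.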